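The source may report more compounds than this note shows. Statements on the series, on what has been measured and on what is new or still open speak of the compounds shown alone.

Measured compounds in a functional assay on MDA-MB-435 cells (Homo sapiens) for inhibition, read by sulforhodamine B assay, with a stated time of 48 h, tested at 100 uM; on this read-out higher numbers stand for a weaker effect at the one concentration tested and lower numbers for a stronger effect:
- compound 1 `O=C(Nc1cccc(-n2cc(-c3ccncc3)c(-c3cc(O)cc(Cl)c3)n2)c1)Nc1ccc(Cl)c(C(F)(F)F)c1`: compound 1 gives -93%
- compound 2 `O=C(Nc1cccc(-n2cc(-c3ccncc3)c(-c3cc(O)cc(Cl)c3)n2)c1)Nc1ccc(Cl)c(Cl)c1`: compound 2 gives -45%

Going by the values given here, on these two numbers compound 1 stands lowest, that is, with the stronger effect of the pair; the only measured step is a number 48 percentage points higher from compound 1 to compound 2 (beyond the scatter), which swaps one group at the far end of the urea. Compound 3 `COc1cc(Cl)cc(-c2nn(-c3cccc(NC(=O)Nc4ccc(Cl)c(C(F)(F)F)c4)c3)cc2-c2ccncc2)c1` keeps everything of compound 1 except (methyl in place of hydrogen on an oxygen on an aromatic ring). Among the compounds with values here, this is a change in a different part of the molecule from the measured step, so that step does not bear on it, and there is no measured pair that tests capping the hydroxy as methoxy. With no guide either way, the step from compound 1 to compound 3 is expected to be small, around a number 13 percentage points higher from compound 1 to compound 3 (beyond the scatter), leaving compound 3 at an estimated -80%, within a range of -100% to -45%.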

Compound 3, a percentage reported as activity, at one concentration (the size of the read-out at that concentration, not a potency): -40%
Estimate against measurement, compound 3: 40 percentage points below; the whole stated range lies below it.
By their numbers in this assay, from the lowest: compound 1; then compounds 2 and 3 (each within the scatter of the next).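

In this assay the change from hydroxy to methoxy gives a number 53 percentage points higher from compound 1 to compound 3 (beyond the scatter) and so shows that this oxygen is a sensitive place in the molecule. One added methyl here moves the read-out by a large step, just as the earlier swap at the far end of the urea did, and in this pair the free hydroxy goes with the stronger effect. Nothing at hand explains why this small change counts for so much.

From the compounds shown here alone, it stays open whether the hydrogen on this oxygen is what matters or whether the added carbon is what harms, and an amine or a longer chain such as ethoxy in this place would help to separate the two. Going by these compounds, it is also open whether the methoxy step would keep its size on the dichloro end of compound 2.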